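This account rests on a few compounds, and the source may have more. Where it says the series, first, only, none or still open, it means among the compounds named here.

Measured in a functional assay on A549 cells (Homo sapiens) for inhibition, read by MTT assay, with a stated time of 48 h; a lower number here means a stronger inhibitor, a higher number a weaker inhibitor:
Compound 1 `O=[N+]([O-])c1ccc(C(c2c[nH]c3ccc([N+](=O)[O-])cc23)c2c[nH]c3ccc([N+](=O)[O-])cc23)cc1`: > 100000 nM (a limit)
Compound 2 `CCCCCCCC(c1c[nH]c2ccc([N+](=O)[O-])cc12)c1c[nH]c2ccc([N+](=O)[O-])cc12`: 12500 nM
Compound 3 `N#Cc1ccc2[nH]cc(C(c3ccc(Cl)cc3)c3c[nH]c4ccc(C#N)cc34)c2c1`: > 100000 nM (a limit)

Compound 3 gives no number, only > 100000 nM, which is a limit. Compound 4 `CCCCCCCC(c1c[nH]c2ccc(C#N)cc12)c1c[nH]c2ccc(C#N)cc12` carries heptyl in place of 4-chlorophenyl on a saturated chain carbon bound to two aromatic carbons. The closest measured precedent is an at least 8.0-fold lower number from compound 1 to compound 2 (0.90 log units; beyond the scatter), where heptyl replaces 4-nitrophenyl at the same place, though on a different core. A step of similar size toward a lower number is therefore expected in this assay. The expected change is an at least 6.6-fold lower number from compound 3 to compound 4 (0.82 log units; beyond the scatter). For compound 4 the estimate is 15000 nM, with an expected range of 5000 nM to 50000 nM.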

Compound 4, half-maximal inhibitory concentration: 26000 nM
Estimate against measurement, compound 4: 1.7-fold (0.24 log units) below; measured number inside the range.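

In this assay, the step with heptyl in place of 4-chlorophenyl on a saturated chain carbon bound to two aromatic carbons is an at least 3.8-fold lower number from compound 3 to compound 4 (0.58 log units; beyond the scatter). The direction now holds for a second pair of compounds, on a nitrile-bearing core as well as the nitro-bearing core of compound 1 and compound 2. The true size of each step stays unknown, and only its minimum can be read: the limit of > 100000 nM in this assay, at which 2 of the 4 values shown sit.

Open, on these data alone, is how chain length matters, for example a butyl or a decyl chain at this place. Also open, as far as these compounds go, is whether a terminal amine or carboxylic acid on the heptyl chain would be tolerated.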